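The source may report more compounds than this note shows. Statements on the series, on what has been measured and on what is new or still open speak of the compounds shown alone.

Working notes on the series. Compound 1 `CC(=O)Nc1cc(NC(=O)c2ccc3c(c2)OCCO3)ccc1C` gives 12900 nM in a functional assay on A375P cells (Homo sapiens) for antiproliferative activity; on this read-out lower numbers stand for stronger inhibition and higher numbers for weaker inhibition. Compound 3 `Cc1ccc(NC(=O)c2ccc3c(c2)OCCO3)cc1NC(=O)c1ccccc1` carries the change (phenyl in place of methyl on a carbonyl carbon). In this assay compound 3 gives > 30000 nM, which is a limit of the assay and not a number. The step is an at least 2.3-fold higher number from compound 1 to compound 3 (0.36 log units; beyond the scatter). Compound 2 `CC(=O)Nc1cc(NC(=O)c2cc(=O)c3ccccc3o2)ccc1C` has a different core; the difference between the two cores is not broken down here. In this assay compound 2 gives > 30000 nM, again a limit of the assay. Compound 4 `Cc1ccc(NC(=O)c2cc(=O)c3ccccc3o2)cc1NC(=O)c1ccccc1` stands to compound 2 as compound 3 stands to compound 1, through the same change, (phenyl in place of methyl on a carbonyl carbon), at an identical place. Two of the three values sit at the limit (the limit of > 30000 nM in this assay, at which 2 of the 3 values shown sit). The step from compound 2 to compound 4 is expected to be a step that the limit leaves unreadable from compound 2 to compound 4, resting on compound 1 to compound 3 giving an at least 2.3-fold higher number from compound 1 to compound 3 (0.36 log units; beyond the scatter). Compound 4 is estimated at 80000 nM, between 30000 nM and 300000 nM, most likely reported only as a limit.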

Compound 4, half-maximal inhibitory concentration: > 30000 nM
Compound 4: a limit, no number; the forecaster's own chance of this, stated with the estimate: 85%; the middle value is on the limit's open side.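

No step can be read between compound 2 and compound 4, as both values are limits of the assay and not numbers: the limit of > 30000 nM in this assay, at which 3 of the 4 values shown sit.

Going by these compounds, whether phenyl in place of methyl on a carbonyl carbon changes the read-out on the core of compound 2 stays open.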